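Replacing the 4-chlorophenyl amide of compound 3

This account rests on a few compounds, and the source may have more. Where it says the series, first, only, none or still open, it means among the compounds named here.

- compound 1 `COc1ccc(-n2nc(C(=O)Nc3ccncc3)cc2-c2ccc(Cl)cc2)nn1` gives 110 nM
- compound 2 `COc1ccc(NC(=O)c2cc(-c3ccc(Cl)cc3)n(-c3ccc(OC)nn3)n2)cc1` gives 400 nM
- compound 3 `COc1ccc(-n2nc(C(=O)Nc3ccc(Cl)cc3)cc2-c2ccc(Cl)cc2)nn1` gives 610 nM

In a functional assay on a cell-free system (Platelet, plasma, Homo sapiens) for inhibition, read by turbidimetry, with a stated time of 3 min (a higher number here means a weaker inhibitor, a lower number a stronger inhibitor), compound 3 stands apart from compound 1 only: the data show a 5.5-fold higher number from compound 1 to compound 3 (0.74 log units; beyond the scatter) and also a 1.5-fold higher number from compound 2 to compound 3 (0.18 log units; within the scatter).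

Compound 4 `COc1ccc(-n2nc(CCC(=O)N3CCOCC3)cc2-c2ccc(Cl)cc2)nn1` carries 2-((morpholin-4-yl)carbonyl)ethyl in place of (4-chlorophenyl)carbamoyl on an aromatic carbon. Going by the values given here, no measured step makes this change. The nearest are swaps on the amide-type nitrogen, a 3.6-fold higher number from compound 1 to compound 2 (0.56 log units; beyond the scatter) and a 5.5-fold higher number from compound 1 to compound 3 (0.74 log units; beyond the scatter), so a modest step to a lower number is expected, with the direction uncertain. The estimated step is a 2.4-fold lower number from compound 3 to compound 4 (0.39 log units; beyond the scatter). For compound 4 the expected value is 250 nM, with an estimated range from 40 nM to 1500 nM.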

Compound 4, half-maximal inhibitory concentration: 1080 nM
Estimate against measurement, compound 4: 4.3-fold (0.64 log units) below, within the range that was stated.
By their numbers in this assay, from the lowest: compound 1; then compounds 2, 3 and 4 (each within the scatter of the next, the first and the last beyond it).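

In this assay, the aromatic amide of compound 3 can give way to 2-((morpholin-4-yl)carbonyl)ethyl, which has 0 hydrogen-bond donors, with a 1.8-fold higher number from compound 3 to compound 4 (0.25 log units; within the scatter) staying within the scatter. The same replacement shows a 9.8-fold higher number from compound 1 to compound 4 (0.99 log units; beyond the scatter) when set against the pyridin-4-yl amide, so this group does not match compound 1. No supporting measurement explains either step. As far as these compounds go, it remains open whether a piperidine ring or a dimethylamide would serve in place of morpholine. A longer chain or a terminal carboxylic acid at this position is also an open question.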